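Dropping the ethyl group from compound 1

This account rests on a few compounds, and the source may have more. Where it says the series, first, only, none or still open, it means among the compounds named here.

Within the data shown here, compound 1 (`CCNC(=O)/C=C1\CCc2ccc(F)cc21`) gives 136 mg/kg in a functional assay on the whole organism with Mus musculus as the target, in the rotarod test (a lower number here means that less compound is needed, a higher number that more compound is needed for the effect), and holds the highest of the two numbers so far. Compound 2 (`Cc1cccc2c1/C(=C/C(N)=O)CC2`) comes nearest with 56 mg/kg as a lower number, and this gap lies beyond the scatter. Compound 3 (`NC(=O)/C=C1\CCc2cc(F)ccc21`) reads > 100 mg/kg and this is a limit of the assay, not a number.

Compound 4 (`NC(=O)/C=C1\CCc2ccc(F)cc21`) has hydrogen in place of ethyl on an amide-type nitrogen relative to compound 1. Among the measured compounds shown here, no measured pair isolates this change, so any forecast rests on thin ground. The expectation of a lower number leans on compound 2 with its 56 mg/kg reading. The expected change is a 1.9-fold lower number from compound 1 to compound 4 (0.29 log units; within the scatter) in this assay and would sit close to the scatter. A reading that reaches only a limit also remains possible for compound 4. For compound 4 the estimated value is 70 mg/kg with an expected range from 30 mg/kg to 160 mg/kg in this series.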

Compound 4, dose for half-maximal effect: 90 mg/kg
For compound 4 the middle estimate is 1.3-fold (0.11 log units) below the measured one, within the range that was stated.
By their numbers in this assay, from the lowest: compounds 2, 4 and 1 (each within the scatter of the next, the first and the last beyond it).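

Hydrogen in place of ethyl on the amide-type nitrogen gives a 1.5-fold lower number from compound 1 to compound 4 (0.18 log units; within the scatter), the first step in the series that isolates a single place. In this assay, compound 1 and compound 4 stay within the scatter of each other, so this pair shows no need for the ethyl group at this nitrogen for a reading in this range. Compound 3 also carries hydrogen on that nitrogen, and its reading is a limit, not a number: the limit of > 100 mg/kg in this assay, at which 1 of the 4 values shown sits.

This single step says nothing about a longer chain such as butyl, a ring amine such as piperidine on that nitrogen, or a carboxylic acid in place of the amide. From the compounds shown here alone, how the place of the fluorine on the shared core bears on the number also stays open while compound 3 stands as a limit.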